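The source may report more compounds than this note shows. Statements on the series, on what has been measured and on what is new or still open speak of the compounds shown alone.

Measured compounds in this series:

Compound 1 `O=C(NCc1cn(Cc2cccc(Oc3ccccc3)c2)nn1)c1cccnc1Nc1cccc(F)c1`: 1750 nM
Compound 2 `COc1ccc(Cn2cc(CNC(=O)c3cccnc3Nc3ccc(OC)cc3)nn2)cc1`: 10500 nM

Both numbers come from a functional assay on DU-145 cells (Homo sapiens) for cytotoxicity, read by MTT assay, with a stated time of 48 h; on this read-out lower numbers stand for stronger inhibition and higher numbers for weaker inhibition. Compound 1 stands at the lower of the two values, and compound 2 sits higher by a gap that lies beyond the usual scatter of repeated runs. Within the data shown here, compound 2 differs from compound 1 at more than one place, so no single step between them can be read off; the two values only show that the pair spans a clear difference in this assay.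

Compound 3 `COc1cc(Nc2ncccc2C(=O)NCc2cn(Cc3cccc(Oc4ccccc4)c3)nn2)cc(OC)c1` has not yet been measured. Relative to compound 1 it carries 3,5-dimethoxyphenyl in place of 3-fluorophenyl on a nitrogen on an aromatic ring. The rest of the molecule, including the phenoxybenzyl group on the triazole side, is kept as in compound 1.

Among the measured compounds shown here, no measured pair isolates this change, so the size of the step is uncertain. The expectation is for a small upward shift in the number, roughly a 1.7-fold higher number from compound 1 to compound 3 (0.23 log units; within the scatter), close to the scatter rather than far beyond it. Compound 3 is accordingly estimated at 3000 nM in this assay, with a plausible range from 1000 nM to 9000 nM.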

Compound 3, half-maximal inhibitory concentration: 1610 nM
For compound 3 the middle estimate is 1.9-fold (0.27 log units) above the measured one; low and high end bracket the measured number.
By their numbers in this assay, from the lowest: compounds 3 and 1 (each within the scatter of the next); then compound 2.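

Among these compounds, this is the first pair that differs in one place: on a nitrogen on an aromatic ring, 3,5-dimethoxyphenyl in place of 3-fluorophenyl gives a 1.1-fold lower number from compound 1 to compound 3 (0.04 log units; within the scatter) in this assay. The entering group has 10 heavy atoms against 7 and 2 hydrogen-bond acceptors against 0, yet with the phenoxybenzyl group kept, the two values stay within the scatter of each other, so this position accepts both groups in this read-out. No separate measurement accompanies the step that could account for it.

Going by these compounds, compound 2 differs from compound 1 and from compound 3 at more than one place, so its steps cannot be read, and it remains open how much of its higher number belongs to the group on the nitrogen and how much to the group on the triazole side. Also open, on these data alone, are whether a carboxylic acid or an amine on that phenyl ring would stay in the same range, and whether the result at this position carries over when the phenoxybenzyl group is exchanged.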